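A methylcarbamoyl swap on compound 3

This account rests on a few compounds, and the source may have more. Where it says the series, first, only, none or still open, it means among the compounds named here.

Measured in an ADME assay on microsomes from liver (Rattus norvegicus) for metabolic stability; a lower number here means that the compound disappears faster, a higher number that the compound lasts longer:
Compound 1 `COc1cc(OCc2csc(-c3ccc(C(F)(F)F)cc3)n2)c2cc(-c3cn4nc(OC)sc4n3)oc2c1`: 1.42 h
Compound 2 `COc1cc(OCc2cccc(-c3ccc(OC)nc3)c2)c2cc(-c3cn4nc(OC)sc4n3)oc2c1`: 0.633 h
Compound 3 `COc1cc(OCc2csc(-c3ccc(C(C)(C)O)cc3)n2)c2cc(-c3cn4nc(OC)sc4n3)oc2c1`: 1.15 h

Compound 3, at 1.15 h, cannot be ranked against compound 1 or compound 2, since its gaps to both lie within the usual scatter of repeated measurements.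

Compound 4 `CNC(=O)c1ccc(-c2nc(COc3cc(OC)cc4oc(-c5cn6nc(OC)sc6n5)cc34)cs2)cc1` has not yet been measured. It keeps the rest of compound 3 and changes one group: methylcarbamoyl in place of 1-hydroxy-1-methylethyl on an aromatic carbon. In words, methylcarbamoyl stands in place of 1-hydroxy-1-methylethyl on an aromatic carbon, para to a large group.

Within the data shown here, only one measured step bears on this change. On the same aromatic carbon, 1-hydroxy-1-methylethyl in place of trifluoromethyl gave a 1.2-fold lower number from compound 1 to compound 3 (0.09 log units; within the scatter). That step shows a swap at this place that did not move the half-life beyond the scatter. Among the measured compounds shown here, it is a single example, however, and no measured compound carries methylcarbamoyl, so the evidence is thin and the range must stay wide.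

In this assay, no step beyond the scatter is therefore expected, and the estimate is a 1.2-fold lower number from compound 3 to compound 4 (0.06 log units; within the scatter). For compound 4 the estimated half-life is 1 h, with an expected range of 0.5 h to 2 h.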

Compound 4, half-life: 0.517 h
Compound 4: middle estimate off by 1.9-fold (0.29 log units), on the high side; measured number inside the range.
By their numbers in this assay, from the lowest: compounds 4, 2, 3 and 1 (each within the scatter of the next, the first and the last beyond it).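

In this assay, the group on this aromatic carbon can make a difference to the half-life: methylcarbamoyl in place of 1-hydroxy-1-methylethyl gave a 2.2-fold lower number from compound 3 to compound 4 (0.35 log units; beyond the scatter), whereas the earlier swap at the same carbon gave only a 1.2-fold lower number from compound 1 to compound 3 (0.09 log units; within the scatter). Methylcarbamoyl in place of trifluoromethyl gave a 2.7-fold lower number from compound 1 to compound 4 (0.44 log units; beyond the scatter), so the new group stands apart from both groups measured earlier at this carbon. Methylcarbamoyl and 1-hydroxy-1-methylethyl match in their counts of heavy atoms, hydrogen-bond donors and hydrogen-bond acceptors, so those counts alone do not separate them, and nothing measured here accounts for the step.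

As far as these compounds go, it remains open whether this step belongs to the methylcarbamoyl group as a whole or to one part of it; a dimethylcarbamoyl group, an unsubstituted carboxamide or a carboxylic acid on the same carbon would help to tell these apart. From the compounds shown here alone, it is also open whether the step would recur on a different core, since these comparisons all rest on a single shared core.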